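The source may report more compounds than this note shows. Statements on the series, on what has been measured and on what is new or still open speak of the compounds shown alone.

In a functional assay on Caco-2 cells (Homo sapiens), read by MTT assay, with a stated time of 48 h (a lower number here means a stronger inhibitor, a higher number a weaker inhibitor), compound 1 (`CCn1c(C(=O)NCCN(C)C)ccc1C(CC)(CC)c1ccc(OCC(O)C(C)(C)C)c(C)c1`) gives 1300 nM and compound 2 (`CCn1c(C(=O)NCCCN(C)C)ccc1C(CC)(CC)c1ccc(OCC(O)C(C)(C)C)c(C)c1`) gives 1900 nM. Lengthening the chain that carries the dimethylamino group makes a 1.5-fold higher number from compound 1 to compound 2 (0.16 log units; within the scatter). Compound 3 (`CCn1c(C(=O)N(C)CCC#N)ccc1C(CC)(CC)c1ccc(OCC(O)C(C)(C)C)c(C)c1`) shares the core of these two compounds but carries a (2-cyanoethyl)(methyl)amino group on the carbonyl carbon. Compound 3 gives > 50000 nM, which is a limit of the assay and not a number.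

The two steps into compound 3 are both large: an at least 38-fold higher number from compound 1 to compound 3 (1.58 log units; beyond the scatter), and an at least 26-fold higher number from compound 2 to compound 3 (1.42 log units; beyond the scatter). Both exchange the whole amine side chain, so they show how much that part of the molecule matters in this assay.

Compound 4 (`C=CCN(C)C(=O)c1ccc(C(CC)(CC)c2ccc(OCC(O)C(C)(C)C)c(C)c2)n1CC`) changes compound 3 only at the far end of that chain: vinyl in place of cyanomethyl on a saturated chain carbon bound to an amide-type nitrogen. Like compound 3, compound 4 has no dimethylamino group, and no measured step tests this particular exchange. The large steps therefore do not apply here, and no step beyond the scatter is expected, though a modest fall in the number remains possible. The estimated change is a number no higher from compound 3 to compound 4 (the limit leaves the size open). For compound 4 the expected value is 50000 nM, with an estimated range of 20000 nM to 100000 nM.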

Compound 4, half-maximal inhibitory concentration: > 50000 nM
Compound 4: only a limit was reported; the forecaster's own chance of this, stated with the estimate: 65%; the middle value lies on the limit itself.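

In this assay compound 4 gives > 50000 nM, which is a limit of the assay and not a number. With vinyl in place of cyanomethyl and no nitrile left in the side chain, the steps from the amine-bearing compounds remain large, an at least 26-fold higher number from compound 2 to compound 4 (1.42 log units; beyond the scatter) and an at least 38-fold higher number from compound 1 to compound 4 (1.58 log units; beyond the scatter), so the loss seen with compound 3 does not depend on that nitrile. The step between compound 3 and compound 4 cannot be read, because both compounds sit at the same limit: the limit of > 50000 nM in this assay, at which 2 of the 4 values shown sit.

Compound 1 and compound 2 carry both a dimethylamino group and the amide hydrogen, while compound 3 and compound 4 have neither, so these compounds cannot show which of the two features matters, or whether both do. A chain ending in a primary amine or a carboxylic acid, on an amide-type nitrogen with or without the methyl group, would help separate the role of the amine from that of the amide hydrogen.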